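This account rests on a few compounds, and the source may have more. Where it says the series, first, only, none or still open, it means among the compounds named here.

Measured compounds in an assay on isolated protein for binding affinity to Melanocortin receptor 4 (Homo sapiens); on this read-out lower numbers stand for stronger inhibition and higher numbers for weaker inhibition:
compound 1, `COc1ccc(Br)cc1CCc1c(Cl)cccc1-c1ncc2n1CCCC2`, gives 340 nM
compound 2, `CCc1cnc(-c2ccccc2CCc2cc(Br)ccc2OC)n1C`, gives 320 nM
compound 3, `COc1ccc(Br)cc1CCc1ccccc1-c1nc(C(C)C)cn1C`, gives 1600 nM

Among these three, compound 2 has the lowest number, yet compound 1 sits so close to it that the two cannot be told apart within the usual scatter of this assay. Compound 3, which differs from compound 2 only in the group attached at the same place on the shared core, gives a number far enough away to lie beyond that scatter.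

Compound 4, `COc1ccc(Br)cc1CCc1ccccc1-c1nc(C)c(C)n1C`, has not yet been measured. Compared with compound 2 it is built from the same atoms joined differently: 1,4,5-trimethyl-1H-imidazol-2-yl in place of 5-ethyl-1-methyl-1H-imidazol-2-yl on an aromatic carbon. In effect, the ethyl chain of compound 2 is redistributed as two methyl groups on the five-membered aromatic ring.

Going by the values given here, no pair of measured compounds differs in exactly this way, so the size of the step in this assay can only be guessed. Compound 3 suggests that changing the substitution on this ring can weaken binding noticeably, because compound 3 gives 1600 nM against the lower number of compound 2. Compound 4 is therefore expected to come out near 550 nM, with a plausible range from 200 nM to 1500 nM. The step from compound 2 to compound 4 is expected to be a 1.7-fold higher number from compound 2 to compound 4 (0.24 log units; within the scatter), a mild weakening that may not exceed the scatter.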

Compound 4, inhibition constant: 140 nM
The estimate for compound 4 lay 3.9-fold (0.59 log units) above the measured number, outside the stated range (below it).
By their numbers in this assay, from the lowest: compound 4; then compounds 2 and 1 (each within the scatter of the next); then compound 3.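

The change from 5-ethyl-1-methyl-1H-imidazol-2-yl to 1,4,5-trimethyl-1H-imidazol-2-yl in this assay gives a 2.3-fold lower number from compound 2 to compound 4 (0.36 log units; beyond the scatter) and shows that this position, on an aromatic carbon ortho to a large group, responds to how the same atoms are arranged, not only to which atoms are present. Among the earlier compounds, the only other change in this group was the one leading to compound 3 at 1600 nM with a higher number than compound 2, whereas this change moves the number down, even though the group that leaves and the group that enters match in heavy atoms, hydrogen-bond donors and hydrogen-bond acceptors. No measurement offered here explains the difference between these two arrangements.

The compounds shown leave open whether both methyl groups on the ring carbons are needed for the lower number, and whether the same change would give a similar step on the chlorine-bearing core of compound 1. They also leave open how a propyl chain, an amine or a carboxylic acid on this five-membered aromatic ring would behave in this assay and whether any of these would keep the number low.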